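Compound 4: amino in place of dimethylamino

The source may hold more compounds than are shown below. What is called first, only, known or untested is meant among the compounds shown, and "the series" means these compounds.

In a functional assay on SW480 cells (Homo sapiens) for antiproliferative activity, read by MTT assay, with a stated time of 48 h (on this read-out higher numbers stand for weaker inhibition and lower numbers for stronger inhibition), compound 1 (`CCCCC(CCO)n1cnc2c(N)ncnc21`) gives > 50000 nM, a limit. Compound 2 (`CCCCCC(CCO)n1cnc2c(N)ncnc21`), also carrying the amino group, gives > 50000 nM, again a limit. Compound 3 (`CCCCCCCC(CCO)n1cnc2c(N(C)C)ncnc21`) gives > 50000 nM, likewise a limit, so it offers no number to start from. Compound 3 stands with the others at the limit of > 50000 nM in this assay, at which 3 of the 3 values shown sit.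

Compound 4 (`CCCCCCCC(CCO)n1cnc2c(N)ncnc21`) has amino in place of dimethylamino on an aromatic carbon. For the measured compounds named here, the only measured step is a step that the two limits leave unreadable from compound 1 to compound 2. It lies on the chain, not at this group, and offers no size to carry over. The expected change is an at least 1.1-fold lower number from compound 3 to compound 4 (0.04 log units; that floor lies within the scatter), small and toward stronger inhibition if readable at all, with another limit quite likely. For compound 4 the estimate is 45000 nM, with an expected range of 15000 nM to 80000 nM.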

Compound 4, half-maximal inhibitory concentration: > 50000 nM
Compound 4: a limit, no number (the forecaster's own chance of this, stated with the estimate: 65%); middle value at least 1.1-fold (0.04 log units) away from the limit.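

Compound 4 gives a limit, as do compound 1, compound 2 and compound 3, so no step among these compounds can be read in this assay. Whether the chain or the amino and dimethylamino groups affect inhibition stays open: the limit of > 50000 nM in this assay, at which 4 of the 4 values shown sit.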